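A few compounds are considered here, and "the series" means these few. Any claim that something is new, unique, unknown or untested is made for them only; others in the source may bear on it.

Compound 2 `CCC(CO)NC(=O)c1cc2cccc(OC)c2oc1=N` stands lowest of the two numbers seen so far in an assay on CHO cells for displacement of a labelled ligand from adenosine receptor A1 (Homo sapiens), read by scintillation counting, with a stated time of 60 min, tested at 10 uM; on this read-out higher numbers stand for more inhibition at the one concentration tested (going by the name of the read-out) and lower numbers for less inhibition: compound 2 gives 24%, while compound 1 `COc1cccc2cc(C(=O)NCCO)c(=N)oc12` gives 47%. Among the compounds with values here, the single step known, a number 23 percentage points lower from compound 1 to compound 2 (beyond the scatter), moved from a hydrogen to an ethyl on a saturated chain carbon. Compound 3 `COc1cccc2cc(C(=O)NC3CCCCC3)c(=N)oc12` differs from compound 2 by cyclohexyl in place of 1-(hydroxymethyl)propyl on an amide-type nitrogen. Within the data shown here, no measured step shows this change, and the one step known concerns a different group, so compound 3 is expected to stay near compound 2 with a number 1 percentage points higher from compound 2 to compound 3 (within the scatter), and its value is estimated at 25%, within 5% to 50%.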

Compound 3, a percentage reported as inhibition, at one concentration (the size of the read-out at that concentration, not a potency): 40%
The estimate for compound 3 lay 15 percentage points below the measured number; measured number inside the range.
By their numbers in this assay, from the lowest: compound 2; then compounds 3 and 1 (each within the scatter of the next).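

In this assay cyclohexyl in place of 1-(hydroxymethyl)propyl on the amide-type nitrogen gives a number 16 percentage points higher from compound 2 to compound 3 (beyond the scatter) and shows that this position can carry a ring. Cyclohexyl in place of 2-hydroxyethyl gives a number 7 percentage points lower from compound 1 to compound 3 (within the scatter) so the hydroxyl is not needed here to hold the number, since cyclohexyl has no hydrogen-bond donor or acceptor. Nothing shown explains these numbers. Going by these compounds, it remains open whether a phenyl ring or a cyclopentyl ring on this nitrogen would behave like cyclohexyl. On these data alone, whether an amine or a carboxylic acid on the chain would hold the number is equally open.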